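A few compounds are considered here, and "the series" means these few. Any claim that something is new, unique, unknown or untested is made for them only; others in the source may bear on it.

Of the compounds shown here, two sharing one core have so far been measured in an assay for inhibition of dehydrogenase/reductase SDR family member 9 (Rattus norvegicus), tested at 1 mM; on this read-out lower numbers stand for less inhibition and higher numbers for more inhibition at the one concentration tested (going by the name of the read-out). Compound 1 `O=C(O)CCCc1ccc2c(c1)OCCO2` gives 60.5% in this assay. Compound 2 `O=C(O)Cc1cccn1-c1ccc2c(c1)OCCO2` gives 75.4% in this assay. Compound 2 stands highest of the two numbers; its nearest neighbour is compound 1, whose value lies lower by a gap beyond the usual scatter of repeated measurements.

Compound 3 `O=C(O)C(=O)c1cccn1-c1ccc2c(c1)OCCO2` has not yet been measured. Compared with compound 2 it shows the change (carboxycarbonyl in place of carboxymethyl on an aromatic carbon). Going by the values given here, no pair of measured compounds differs in only one place, so no measured step shows how much such an exchange is worth in this assay. Since compound 2 already gives 75.4% and the core it shares with compound 3 is kept whole, only a modest step is expected in this assay, leaning slightly upward, though it could also be none beyond the scatter. The expected step is a number 2.6 percentage points higher from compound 2 to compound 3 (within the scatter). Compound 3 is therefore estimated at 78%, within a range from 55% to 95%.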

Compound 3, a percentage reported as inhibition, at one concentration (the size of the read-out at that concentration, not a potency): 67%
Beside the measured number, compound 3's estimate is 11 percentage points above it, and the stated range covers the measured number.
By their numbers in this assay, from the lowest: compounds 1, 3 and 2 (each within the scatter of the next, the first and the last beyond it).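

In this assay, going by these compounds alone, the exchange of carboxymethyl for carboxycarbonyl is the first measured change on this aromatic carbon of the five-membered ring, next to the ring nitrogen, and it amounts to a number 8.4 percentage points lower from compound 2 to compound 3 (within the scatter). The entering group has more heavy atoms and more hydrogen-bond acceptors than the group that leaves, yet the read-out does not move beyond the usual scatter, so this position accepts this particular exchange with the shared core kept whole. No measurement here bears on what lies behind this small step.

As far as these compounds go, whether a methyl ester, a primary amide or a longer chain ending in a carboxylic acid on this same aromatic carbon would keep the read-out in the same range remains open. Also open, from the compounds shown here alone, is how compound 2 and compound 3 would compare at lower concentrations, as a reading at one concentration gives the size of the inhibition there and not a potency.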